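A few compounds are considered here, and "the series" means these few. Any claim that something is new, unique, unknown or untested is made for them only; others in the source may bear on it.

Measured so far in a functional assay on A-375 cells (Homo sapiens) for antiproliferative activity, read by CCK-8 assay, with a stated time of 72 h, tested at 8 uM; a lower number here means a weaker effect, a higher number a stronger effect of the compound at the concentration tested:
compound 1 `Nc1ccccc1NC(=O)c1ccc(CSC(=S)N2CCN(C3CCCCC3)CC2)cc1`: 89.9%
compound 2 `Nc1ccccc1NC(=O)c1ccc(CSC(=S)N2CCc3cc([N+](=O)[O-])ccc32)cc1`: 29.5%
compound 3 `CCN(Cc1ccncc1)C(=S)SCc1ccc(C(=O)Nc2ccccc2N)cc1`: 86.2%

Compound 1 gives the highest number of the three. Compound 3 lies close to it, within the scatter, so no order between these two can be drawn. Compound 2 lies well below compound 1, beyond the scatter. The next compound, compound 4 `N#Cc1ccc(N2CCN(C(=S)SCc3ccc(C(=O)Nc4ccccc4N)cc3)CC2)cc1`, differs from compound 1 in one place: 4-cyanophenyl in place of cyclohexyl on an amine nitrogen in a ring. For the measured compounds named here, no pair of measured compounds spans this kind of change, so the expected size of the step rests on compound 1 alone. A downward step is expected, of a size that may reach beyond the scatter, since the read-out of compound 1 leaves little room to rise. Compound 4 is estimated at 70%, between 35% and 92%, meaning an expected step of a number 19.9 percentage points lower from compound 1 to compound 4 (beyond the scatter).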

Compound 4, a percentage reported as inhibition, at one concentration (the size of the read-out at that concentration, not a potency): 62.9%
The estimate for compound 4 lay 7.1 percentage points above the measured number; low and high end bracket the measured number.
By their numbers in this assay, from the lowest: compound 2; then compound 4; then compounds 3 and 1 (each within the scatter of the next).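

In this assay, 4-cyanophenyl in place of cyclohexyl on the amine nitrogen in the ring gives a number 27 percentage points lower from compound 1 to compound 4 (beyond the scatter). For the compounds shown here, this is the first single-place step, and it shows that the group at this nitrogen can shift the read-out beyond the scatter. Nothing available accounts for the size of this step.

As far as these compounds go, what remains open is whether the step goes with the aromatic ring or with the nitrile, which a plain phenyl at this nitrogen would separate. From the compounds shown here alone, how a small methyl or a longer alkyl chain would fare there also stays unknown.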